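This account rests on a few compounds, and the source may have more. Where it says the series, first, only, none or still open, it means among the compounds named here.

For the measured compounds named here, compound 2 (`CC(C)=CC[C@H]1C[C@]23C[C@@H](CC=C(C)C)C(C)(C)[C@H]4CCC(C)(C)O[C@]42OC(=O)C(C(=O)c2ccc(O)c(O)c2)=C3OC1(C)C`) carries a 3,4-dihydroxyphenyl group on its core, and in a functional assay on HEL cells (Homo sapiens) for antiproliferative activity, read by MTT assay, with a stated time of 72 h (on this read-out lower numbers stand for stronger inhibition and higher numbers for weaker inhibition), compound 2 gives 4790 nM, the only true number so far. Compound 1 (`COc1ccc(C(=O)Oc2ccc(C(=O)C3=C4OC(C)(C)[C@@H](CC=C(C)C)C[C@@]45C[C@@H](CC=C(C)C)C(C)(C)[C@H]4CCC(C)(C)O[C@]45OC3=O)cc2OC(=O)c2ccc(OC)cc2)cc1`) has ester groups on both of those aromatic oxygens, and its reading of > 20000 nM is a limit and not a number. Compound 3 (`CC(C)=CC[C@H]1C[C@]23C[C@@H](CC=C(C)C)C(C)(C)[C@H]4CCC(C)(C)O[C@]42OC(=O)C(C(=O)c2ccc(OC(=O)c4ccc(Br)cc4)c(OC(=O)c4ccc(Br)cc4)c2)=C3OC1(C)C`) also has ester groups on both oxygens, and its reading of > 20000 nM is likewise a limit.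

Compound 4 (`CCC(=O)Oc1cc(C(=O)C2=C3OC(C)(C)[C@@H](CC=C(C)C)C[C@@]34C[C@@H](CC=C(C)C)C(C)(C)[C@H]3CCC(C)(C)O[C@]34OC2=O)ccc1O`) differs from compound 2 by one change (propanoyl in place of hydrogen on an oxygen on an aromatic ring): propanoyl in place of hydrogen on an oxygen on an aromatic ring, which turns 3,4-dihydroxyphenyl into 4-hydroxy-3-(propanoyloxy)phenyl. One hydroxy group therefore stays free. Going by the values given here, no two measured compounds differ by this change alone, so any forecast is a loose one. Compound 1 and compound 3 have both oxygens capped, whereas compound 4 has only one capped, so it is expected to fall between these cases. In this assay a modest weakening is expected, towards higher numbers, and it may not rise far beyond the usual scatter. The estimated change is a 1.7-fold higher number from compound 2 to compound 4 (0.22 log units; within the scatter) in this direction. For compound 4 the estimated value is 8000 nM (expected range 3000 nM to 20000 nM).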

Compound 4, half-maximal inhibitory concentration: 9710 nM
Beside the measured number, compound 4's estimate is 1.2-fold (0.08 log units) below it; the measured number falls inside the stated range.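

In this assay, placing propanoyl on an oxygen on an aromatic ring gives a 2.0-fold higher number from compound 2 to compound 4 (0.31 log units; beyond the scatter), so this single change costs some activity, but only a modest amount. For the compounds shown here, compound 1 and compound 3 have both aromatic oxygens capped and their readings are limits, not numbers, so they could not give the size of a step; compound 4 is the first ester here that does. With one hydroxy group still free and propanoyl on the other oxygen, compound 4 gives a true number and does not sit at the limit: the limit of > 20000 nM in this assay, at which 2 of the 4 values shown sit.

The compounds shown leave open whether the step depends on which of the two oxygens carries the propanoyl group, since only the 4-hydroxy-3-(propanoyloxy)phenyl arrangement appears here. On these data alone, it is also open whether a methyl ether on the same oxygen, or a longer acyl chain such as hexanoyl, would give a similar step or a larger one.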